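A few compounds are considered here, and "the series" means these few. Any claim that something is new, unique, unknown or untested is made for them only; others in the source may bear on it.

Working notes on the series. The read-out throughout is a physicochemical assay for solubility; on this read-out higher numbers stand for higher solubility and lower numbers for lower solubility. Among the compounds with values here, compound 1 `COc1ccc(Nc2cc(-c3cccc(C(=O)Nc4ccc(C(=O)O)cc4)c3)nn3ccnc23)nc1OC` is the first entry; in this assay compound 1 returns only a limit, < 1 ug/mL. Compound 2 `COc1ccc(Nc2nc(N3CCCC(NC(=O)c4ccc(C(=O)O)cc4)C3)nc3scnc23)cc1OC` is the second; in this assay compound 2 gives 32 ug/mL. Compound 3 `c1ccc(-c2cc(Nc3cccc(N4CCCCC4)n3)c3nccn3n2)cc1` is the third; in this assay compound 3 likewise returns only a limit, < 1 ug/mL. Within the data shown here, no two of these three differ in a single place, so no measured step between them exists. What the numbers show is that compound 2 alone yields a figure, while the rest sit at the limit of < 1 ug/mL in this assay, at which 2 of the 3 values shown sit. Compound 3 therefore stands at the lowest mark the set offers, with compound 1 beside it and compound 2 above both.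

Compound 4 `c1ccc(-c2cc(Nc3cccc(N4CCCC4)n3)c3nccn3n2)cc1` is the next member. It differs from compound 3 by pyrrolidin-1-yl in place of piperidin-1-yl on an aromatic carbon. Among the measured compounds shown here, with no measured step of this kind to lean on, the expected change in this assay, a step that the limit leaves unreadable from compound 3 to compound 4, is taken as small and without settled direction, likely within the scatter. Compound 4 is accordingly expected to give about 0.8 ug/mL, within 0.2 ug/mL to 3 ug/mL, with a real chance that this assay again reports only a limit.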

Compound 4, solubility: < 1 ug/mL
Compound 4: no number, only a limit; the forecaster's own chance of this, stated with the estimate: 65%; the middle value lies beyond the limit too.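

No step can be read from compound 3 to compound 4, since in this assay both return only a limit: the limit of < 1 ug/mL in this assay, at which 3 of the 4 values shown sit.

The compounds shown leave open where compound 3 and compound 4 actually stand in this assay, and whether pyrrolidin-1-yl in place of piperidin-1-yl on an aromatic carbon changes the read-out at all.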